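The source may hold more compounds than are shown below. What is called first, only, known or untested is meant among the compounds shown, and "the series" means these compounds.

In a functional assay on HL-60 cells (Homo sapiens) for inhibition, with a stated time of 72 h (a higher number here means a weaker inhibitor, a lower number a stronger inhibitor), compound 1 `[N-]=[N+]=NCc1ncnc2c1ncn2[C@@H]1O[C@H](CO)[C@@H](O)[C@H]1O` gives 1880 nM, compound 2 `OC[C@H]1O[C@@H](n2cnc3c(CSCc4ccccc4)ncnc32)[C@H](O)[C@@H]1O` gives 10700 nM and compound 3 `CSCc1ncnc2c1ncn2[C@@H]1O[C@H](CO)[C@@H](O)[C@H]1O` gives 13400 nM. Compound 3 therefore sits at the weak end of this small set, level with compound 2 within the scatter. Putting methylsulfanyl in place of azido is a 7.1-fold higher number from compound 1 to compound 3 (0.85 log units; beyond the scatter), and putting benzylsulfanyl there is a 5.7-fold higher number from compound 1 to compound 2 (0.76 log units; beyond the scatter). Between the two sulfur-bearing groups, the step is a 1.3-fold higher number from compound 2 to compound 3 (0.10 log units; within the scatter), so replacing hydrogen with phenyl on that chain did not separate them.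

Compound 4 `OC[C@H]1O[C@@H](n2cnc3c(CN4CCCCC4)ncnc32)[C@H](O)[C@@H]1O` carries a new group: piperidin-1-yl in place of methylsulfanyl on a saturated chain carbon bound to an aromatic carbon. For the measured compounds named here, no measured compound has a piperidin-1-yl group, so the steps above offer only an indirect guide. The two sulfur-bearing compounds stay close despite their different sizes, while azido stands apart, so a modest shift in either direction remains possible. In this assay, the expected step is a 1.5-fold lower number from compound 3 to compound 4 (0.17 log units; within the scatter), so no clear change is anticipated. Compound 4 is estimated at 9000 nM, with an expected range from 2500 nM to 30000 nM.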

Compound 4, half-maximal inhibitory concentration: 6900 nM
Compound 4: the middle estimate sits 1.3-fold (0.12 log units) above what was measured, within the range that was stated.
By their numbers in this assay, from the lowest: compound 1; then compounds 4, 2 and 3 (each within the scatter of the next).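

Piperidin-1-yl, which has a ring and no sulfur, reads level with both sulfur-bearing groups on this saturated chain carbon in this assay (a 1.9-fold lower number from compound 3 to compound 4 (0.29 log units; within the scatter); a 1.6-fold lower number from compound 2 to compound 4 (0.19 log units; within the scatter)), so sulfur is not needed for a number in this range. Azido and piperidin-1-yl both join the chain carbon through nitrogen, yet they remain apart (a 3.7-fold higher number from compound 1 to compound 4 (0.56 log units; beyond the scatter)), so a nitrogen at that point does not by itself give the number of compound 1. No measurement shown here explains why azido stands apart from the other three groups.

Going by these compounds, it remains open whether a primary amine or a methoxy group at this place would read with azido or with the other three groups. An open-chain diethylamino group would test whether the ring of piperidin-1-yl matters at all.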